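A few compounds are considered here, and "the series" means these few. Any claim that something is new, unique, unknown or untested is made for them only; others in the source may bear on it.

Compound 3, with structure `Nc1nc(N/N=C/C2CCCC2)nc2c1ncn2[C@@H]1O[C@H](CO)[C@@H](O)[C@H]1O`, gives 5.6 nM in an assay on CHO-K1 cells for displacement of a labelled ligand from adenosine receptor A1 (Homo sapiens), read by scintillation counting, with a stated time of 60 min (a lower number here means a stronger inhibitor, a higher number a weaker inhibitor), the lowest of the two numbers in this series. Compound 1, with structure `Nc1nc(N/N=C/c2ccc(-c3ccccc3)cc2)nc2c1ncn2[C@@H]1O[C@H](CO)[C@@H](O)[C@H]1O`, gives 7860 nM in this assay. Compound 2, with structure `CSCC/C=N/Nc1nc(N)c2ncn([C@@H]3O[C@H](CO)[C@@H](O)[C@H]3O)c2n1`, reaches only the limit of > 10000 nM in this assay, and that is a limit rather than a number (the limit of > 10000 nM in this assay, at which 1 of the 3 values shown sits). For the measured compounds named here, the one step that can be measured, an at least 1700-fold lower number from compound 2 to compound 3 (3.25 log units; beyond the scatter), is large. Compound 4, with structure `CN(C)c1ccc(/C=N/Nc2nc(N)c3ncn([C@@H]4O[C@H](CO)[C@@H](O)[C@H]4O)c3n2)cc1`, differs from compound 3 in one place: 4-(dimethylamino)phenyl in place of cyclopentyl on a carbon with a double bond to nitrogen. Going by the values given here, no measured pair makes exactly this change, but compound 1 also carries a six-membered aromatic ring of carbon only on the carbon with a double bond to nitrogen, and compound 1 gives 7860 nM, far above compound 3. A large rise in this assay is therefore expected for compound 4, with an estimated step of a 540-fold higher number from compound 3 to compound 4 (2.73 log units; beyond the scatter). The value expected for compound 4 in this assay is 3000 nM, in a range from 400 nM to 12000 nM.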

Compound 4, inhibition constant: > 10000 nM
Compound 4 gave a limit, no number; the forecaster's own chance of this, stated with the estimate: 15%; middle value at least 3.3-fold (0.52 log units) away from the limit.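

In this assay, 4-(dimethylamino)phenyl in place of cyclopentyl on the carbon with a double bond to nitrogen gives an at least 1700-fold higher number from compound 3 to compound 4 (3.25 log units; beyond the scatter), so a second measured pair at this place now shows a large loss on leaving cyclopentyl, this time with an aromatic ring entering rather than an open chain. Dimethylamino in place of phenyl on the aromatic carbon gives an at least 1.2-fold higher number from compound 1 to compound 4 (0.10 log units; that floor lies within the scatter), so this pair does not separate the two aromatic groups, and the step from compound 2 to compound 4 cannot be read. Compound 4 gives a limit rather than a number, one it shares with compound 2: the limit of > 10000 nM in this assay, at which 2 of the 4 values shown sit.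

As far as these compounds go, whether other non-aromatic rings, such as cyclobutyl or cyclohexyl, would stay close to compound 3, which gives 5.6 nM, remains open. So does how a plain phenyl or a simple butyl chain would behave at this place.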